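The compounds below may be only part of what the source reports. "The series", "measured", "known", "first", "only" and "open" are said of these compounds alone.

Compound 1 `Nc1scc(CN2CCN(c3ccc(Cl)cc3F)CC2)c1C(=O)c1ccc(Cl)cc1` stands lowest of the three numbers seen in a functional assay on CHO cells with adenosine receptor A1 (Homo sapiens) as the target, read by cAMP accumulation and immunoassay, with a stated time of 6 min, tested at 1 uM (a higher number here means a weaker effect of the compound at the concentration tested, a lower number a stronger effect), where compound 1 gives -57%. Compound 2 `COc1ccc(N2CCN(Cc3csc(N)c3C(=O)c3ccc(Cl)cc3)CC2)cc1` gives -15% in this assay, and compound 3 `Nc1scc(CN2CCN(c3cccnc3)CC2)c1C(=O)c1ccc(Cl)cc1` gives -2.7%. Both replacements of the same group on the shared core went the same way: the step of a number 42 percentage points higher from compound 1 to compound 2 (beyond the scatter) and the step of a number 54.3 percentage points higher from compound 1 to compound 3 (beyond the scatter) were both large, and the step of a number 12.3 percentage points higher from compound 2 to compound 3 (beyond the scatter) was modest. Compound 4 `Nc1scc(CN2CCN(c3ccncc3)CC2)c1C(=O)c1ccc(Cl)cc1` carries the change (pyridin-4-yl in place of 4-chloro-2-fluorophenyl on an amine nitrogen in a ring). The closest measured step is that to compound 3, which was large, so a large rise is expected, a number 52 percentage points higher from compound 1 to compound 4 (beyond the scatter). Compound 4 is therefore estimated at -5%, within a range from -25% to 15%.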

Compound 4, a percentage reported as activity, at one concentration (the size of the read-out at that concentration, not a potency): -8.3%
Beside the measured number, compound 4's estimate is 3.3 percentage points above it, within the range that was stated.
By their numbers in this assay, from the lowest: compound 1; then compounds 2, 4 and 3 (each within the scatter of the next, the first and the last beyond it).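

In this assay, pyridin-4-yl in place of pyridin-3-yl makes no clear difference (a number 5.6 percentage points lower from compound 3 to compound 4 (within the scatter)), and neither does pyridin-4-yl in place of 4-methoxyphenyl (a number 6.7 percentage points higher from compound 2 to compound 4 (within the scatter)). The large rise on leaving 4-chloro-2-fluorophenyl therefore holds for a second pyridine as well (a number 48.7 percentage points higher from compound 1 to compound 4 (beyond the scatter)), so the position of the ring nitrogen in the pyridine matters little here. No measurement at hand explains this result. The compounds shown leave open whether the chlorine or the fluorine of the 4-chloro-2-fluorophenyl group accounts for the gap, which 4-chlorophenyl or 2-fluorophenyl on the same amine nitrogen would separate.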